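Benzyl in place of 4-hydroxycyclohexyl: outlook for compound 4

The source may report more compounds than this note shows. Statements on the series, on what has been measured and on what is new or still open speak of the compounds shown alone.

Compound 1 `O=[N+]([O-])c1ccc(NC(=S)NCCNS(=O)(=O)c2ccc(-c3ccccc3O[C@H]3CC[C@@H](O)CC3)s2)cc1` and compound 2 `O=[N+]([O-])c1ccc(NC(=S)NCCNS(=O)(=O)c2ccc(-c3ccccc3OCc3ccccc3)s2)cc1` share one core; compound 3 `O=S(=O)(NCCNC(=S)Nc1cc(C(F)(F)F)cc(C(F)(F)F)c1)c1ccc(-c2ccccc2O[C@H]2CC[C@@H](O)CC2)s1` and the still unmeasured compound 4 `O=S(=O)(NCCNC(=S)Nc1cc(C(F)(F)F)cc(C(F)(F)F)c1)c1ccc(-c2ccccc2OCc2ccccc2)s1` share another, and the difference between the two cores is not broken down here. Within each pair the change is the same: benzyl in place of 4-hydroxycyclohexyl on an oxygen on an aromatic ring from compound 1 to compound 2, and benzyl in place of 4-hydroxycyclohexyl on an oxygen on an aromatic ring from compound 3 to compound 4.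

In a functional assay on HL-60 cells (Homo sapiens) for inhibition, read by CCK-8 assay, with a stated time of 48 h (on this read-out lower numbers stand for stronger inhibition and higher numbers for weaker inhibition), compound 1 reaches only a limit, > 50000 nM. In this assay compound 2 likewise reaches only a limit, > 50000 nM. The step that the two limits leave unreadable from compound 1 to compound 2 therefore carries no readable size; (the limit of > 50000 nM in this assay, at which 2 of the 3 values shown sit). In this assay, among the measured compounds shown here, compound 3 gives 2600 nM, the only number among the three measured values.

For the measured compounds named here, the single measured instance of this change, from compound 1 to compound 2, left both ends at a limit and shows no direction. For compound 4 the change is expected to be close to neutral, a step of a 1.3-fold higher number from compound 3 to compound 4 (0.13 log units; within the scatter) in this assay. Compound 4 is thus estimated at 3500 nM in this assay, within a range from 1200 nM to 12000 nM.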

Compound 4, half-maximal inhibitory concentration: 2100 nM
Compound 4: middle estimate off by 1.7-fold (0.22 log units), on the high side, and the stated range covers the measured number.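

In this assay, the change gives a 1.2-fold lower number from compound 3 to compound 4 (0.09 log units; within the scatter), so the read-out does not tell benzyl and 4-hydroxycyclohexyl apart on this oxygen in the core of compound 3. The same change in the core of compound 1 has no readable size, as both of its compounds sit at a limit of the read-out: the limit of > 50000 nM in this assay, at which 2 of the 4 values shown sit.

That leaves one readable instance of the change, which shows a step within the scatter in a single core and does not show that the step carries over from one core to another.

Open, from the compounds shown here alone, is whether other groups on this oxygen would also leave the read-out in place, for example an amine such as 4-aminocyclohexyl or a longer chain such as phenethyl. Also open, going by these compounds, is whether benzyl in place of 4-hydroxycyclohexyl would read the same in a further core where both compounds give numbers rather than limits.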